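The source may report more compounds than this note shows. Statements on the series, on what has been measured and on what is new or still open speak of the compounds shown alone.

Measured so far in a functional assay on MCF7 cells (Homo sapiens) for inhibition, read by MTT assay, with a stated time of 48 h; a higher number here means a weaker inhibitor, a lower number a stronger inhibitor:
- Compound 1 `CCOC(=O)C1=C(N/C=N/c2nnc(S(N)(=O)=O)s2)Nc2[nH]nc(C)c2C1c1ccc(N(C)C)cc1`: 34500 nM
- Compound 2 `CCOC(=O)C(=NNC1=C(C(=O)OCC)C(c2ccc(N(C)C)cc2)c2c(C)n[nH]c2N1)C(=O)OCC`: 89800 nM

Of these two compounds, compound 2 has the higher number, which makes it the weaker inhibitor in this assay. Compound 3 `CCOC(=O)C1=C(N/N=C(/C(=O)Br)c2ccc(Cl)cc2)Nc2[nH]nc(C)c2C1c1ccc(N(C)C)cc1` keeps the shared core of compound 2 and differs on an amine nitrogen: a group of 12 heavy atoms (8 carbon, 1 nitrogen, 1 oxygen, 1 chlorine, 1 bromine; one six-membered aromatic ring of carbon only) in place of a group of 12 heavy atoms (7 carbon, 1 nitrogen, 4 oxygen; no ring), on an amine nitrogen.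

Among the measured compounds shown here, only one measured step bears on this change, and it falls on the same amine nitrogen: a 2.6-fold higher number from compound 1 to compound 2 (0.42 log units; beyond the scatter). That modest step exchanged one group of similar heavy-atom count for another. For the measured compounds named here, it is a single example, and no measured compound carries the six-membered aromatic ring of carbon only that enters here. A step of similar modest size is therefore the largest one expected in this assay, and most likely none beyond the scatter. Any expected drift is slightly downward, since compound 2 at 89800 nM is the higher of the two values.

The estimated step is a 1.5-fold lower number from compound 2 to compound 3 (0.18 log units; within the scatter). Compound 3 is expected near 60000 nM, with an estimated range of 20000 nM to 150000 nM.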

Compound 3, half-maximal inhibitory concentration: 46300 nM
Estimate against measurement, compound 3: 1.3-fold (0.11 log units) above, within the range that was stated.
By their numbers in this assay, from the lowest: compounds 1, 3 and 2 (each within the scatter of the next, the first and the last beyond it).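

In this assay, the group with a six-membered aromatic ring of carbon only, which also holds chlorine and bromine, gives a 1.9-fold lower number from compound 2 to compound 3 (0.29 log units; within the scatter) and a 1.3-fold higher number from compound 1 to compound 3 (0.13 log units; within the scatter). Compound 3 thus lies within the scatter of both earlier compounds, even though those two lie beyond the scatter of each other, so this amine nitrogen now has a carbon-only aromatic ring alongside a ring with 3 hetero atoms and a group with no ring, and the new group cannot be ranked against either. Nothing measured here accounts for these numbers.

From the compounds shown here alone, the ring, the chlorine and the bromine all enter together in compound 3, so the share of each in its number remains open, as does what a plain phenyl group or a carboxylic acid in place of the bromine-bearing carbonyl would give. All three groups are of similar heavy-atom count, which leaves open how a much smaller group on this amine nitrogen, such as a methyl or an acetyl, would read.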